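A few compounds are considered here, and "the series" means these few. Any claim that something is new, unique, unknown or untested is made for them only; others in the source may bear on it.

Working notes on the series in an assay on cells for agonist activity at ecdysone receptor (Bombyx mori), read by a luciferase reporter, with a stated time of 24 h; on this read-out lower numbers stand for an effect already at smaller amounts and higher numbers for an effect only at larger amounts of compound. Compound 1 `CC(C)(C)N(NC(=O)c1ccccc1)C(=O)c1ccccc1Cl` gives 75.9 nM. Compound 2 `CC(C)(C)N(NC(=O)c1ccccc1Br)C(=O)c1ccccc1Cl` gives 316 nM. Compound 3 `CC(C)(C)N(NC(=O)c1cccc(Br)c1)C(=O)c1ccccc1Cl` gives 191 nM. Among these three numbers compound 3 has the second highest; its nearest is compound 2, and the step of a 1.7-fold lower number from compound 2 to compound 3 (0.22 log units; within the scatter) lies within the scatter, while its furthest is compound 1, with a 2.5-fold higher number from compound 1 to compound 3 (0.40 log units; beyond the scatter) beyond the scatter. The other bromo-for-hydrogen step, a 4.2-fold higher number from compound 1 to compound 2 (0.62 log units; beyond the scatter), is likewise beyond the scatter.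

Compound 4 `CC(C)(C)N(NC(=O)c1cccc(C#N)c1)C(=O)c1ccccc1Cl` has not yet been measured. It differs from compound 3 by cyano in place of bromo on an aromatic carbon. For the measured compounds named here, no measured pair exchanges bromo for cyano, so the only steps that bear on the change are those that placed bromo on the second ring: a 2.5-fold higher number from compound 1 to compound 3 (0.40 log units; beyond the scatter) and a 4.2-fold higher number from compound 1 to compound 2 (0.62 log units; beyond the scatter), both modest, and a 1.7-fold lower number from compound 2 to compound 3 (0.22 log units; within the scatter), within the scatter. The substituent at that position has so far moved this assay by modest amounts at most. Compound 4 is therefore expected near 160 nM, with a range of 60 nM to 450 nM. The expected step of a 1.2-fold lower number from compound 3 to compound 4 (0.08 log units; within the scatter) is thus estimated to remain within the scatter, with no direction claimed.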

Compound 4, half-maximal effective concentration: 955 nM
The estimate for compound 4 lay 6.0-fold (0.78 log units) below the measured number; the measured number lies above the stated range.
By their numbers in this assay, from the lowest: compound 1; then compounds 3 and 2 (each within the scatter of the next); then compound 4.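

In this assay, this place on the ring does not tolerate every group alike: a 5.0-fold higher number from compound 3 to compound 4 (0.70 log units; beyond the scatter) lies beyond the scatter, whereas moving the bromo between the two places, a 1.7-fold lower number from compound 2 to compound 3 (0.22 log units; within the scatter), did not. Cyano is also the first group to give a large step from the unsubstituted compound, a 13-fold higher number from compound 1 to compound 4 (1.10 log units; beyond the scatter), compared with the modest 2.5-fold higher number from compound 1 to compound 3 (0.40 log units; beyond the scatter) for bromo at the same place, and with a 3.0-fold higher number from compound 2 to compound 4 (0.48 log units; beyond the scatter) as well, compound 4 now has the highest number of the four, beyond the scatter of each of the others. No measurement here bears on why the exchange of bromo for cyano raises the number.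

The compounds shown leave open how a methyl, a methoxy, an amine or a carboxylic acid at this place would read in this assay, so one nitrile and one bromo do not yet make a trend across groups. Also open, going by these compounds, are whether cyano on the aromatic carbon that carries bromo in compound 2 would give a step of similar size, and whether any group on this ring can give a number lower than that of compound 1, 75.9 nM.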